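Swapping the aromatic group on the amide side chain

A few compounds are considered here, and "the series" means these few. Any claim that something is new, unique, unknown or untested is made for them only; others in the source may bear on it.

Compound 1 `CN(Cc1ccccc1Cl)C(=O)c1cc2c(Cc3ccccc3)n[nH]c2cc1O` gives 1100 nM
Compound 2 `CN(Cc1ccc(F)cc1)C(=O)c1cc2c(Cc3ccccc3)n[nH]c2cc1O` gives 4100 nM

In a functional assay on A2780 cells (Homo sapiens) for antiproliferative activity, read by resazurin assay, with a stated time of 72 h (a lower number here means a stronger inhibitor, a higher number a weaker inhibitor), compound 2 stands highest of the two measured compounds at 4100 nM and so is the weaker inhibitor of the pair. Compound 3 `COc1cccc(CN(C)C(=O)c2cc3c(Cc4ccccc4)n[nH]c3cc2O)c1OC` keeps the shared core and the amide, and differs from compound 2 in one place: 2,3-dimethoxyphenyl in place of 4-fluorophenyl on a saturated chain carbon bound to an amide-type nitrogen. Among the measured compounds shown here, only one measured step bears on this change. In it, a 3.7-fold higher number from compound 1 to compound 2 (0.57 log units; beyond the scatter) comes from a swap of the aromatic group at the same place, and it is modest but beyond the scatter. For the measured compounds named here, no measured compound carries 2,3-dimethoxyphenyl, so the direction remains uncertain. Going by the values given here, still, the only group measured in place of 4-fluorophenyl gave compound 1 its lower number of 1100 nM in this assay and offers the one available guide. A modest step toward a lower number is therefore expected (a 2.3-fold lower number from compound 2 to compound 3 (0.36 log units; beyond the scatter)). Compound 3 is estimated at 1800 nM with an expected range from 600 nM to 5000 nM in this assay for this measurement.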

Compound 3, half-maximal inhibitory concentration: 4800 nM
Estimate against measurement, compound 3: 2.7-fold (0.43 log units) below; the range from low to high includes it.
By their numbers in this assay, from the lowest: compound 1; then compounds 2 and 3 (each within the scatter of the next).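

In this assay the swap to 2,3-dimethoxyphenyl gives a 1.2-fold higher number from compound 2 to compound 3 (0.07 log units; within the scatter) and so leaves compound 3 level with compound 2, even though the entering group has more heavy atoms and carries two hydrogen-bond acceptors where 4-fluorophenyl has none. Starting instead from 2-chlorophenyl, the same swap gives a 4.4-fold higher number from compound 1 to compound 3 (0.64 log units; beyond the scatter) and is a real step, so two quite different aromatic groups now sit together at this position while the 2-chlorophenyl group of compound 1 stands apart as the strongest inhibitor of the three. No independent measurement is available to explain why these aromatic groups give these numbers.

The compounds shown leave open whether the advantage of compound 1 depends on the chlorine itself or on its place on the ring, a question that 2-fluorophenyl and 4-chlorophenyl analogues would address directly. They also leave open how this position would respond to something other than a substituted phenyl ring, such as an amine, a carboxylic acid or a longer chain leading to the ring.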